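Oxiran-2-yl to vinyl: working notes on compound 3

A few compounds are considered here, and "the series" means these few. Any claim that something is new, unique, unknown or untested is made for them only; others in the source may bear on it.

In a functional assay on MIA PaCa-2 cells (Homo sapiens) for cytotoxicity, read by MTT assay, with a stated time of 24 h (on this read-out higher numbers stand for weaker inhibition and lower numbers for stronger inhibition), compound 2 `C=C1C(=O)O[C@H]2[C@@H](OC(C)=O)[C@@H]1[C@H](OC(=O)C(C)(O)CC)[C@H](C(=C)C=O)[C@@]2(C)[C@@H]1CO1` gives 220 nM and compound 1 `C=C[C@@]1(C)[C@H]2OC(=O)C(=C)[C@H]([C@@H]2OC(C)=O)[C@H](OC(=O)C(C)(C)O)[C@@H]1C(=C)C=O` gives 320 nM so the two numbers lie within the scatter of each other. Compound 3 `C=C[C@@]1(C)[C@H]2OC(=O)C(=C)[C@H]([C@@H]2OC(C)=O)[C@H](OC(=O)C(C)(O)CC)[C@@H]1C(=C)C=O` differs from compound 2 by vinyl in place of oxiran-2-yl on a saturated ring carbon and has vinyl in place of oxiran-2-yl on a saturated ring carbon. Among the compounds with values here, no measured pair isolates this change, so no step beyond the scatter is expected in this assay and no direction is favoured. The expected step of a 1.3-fold higher number from compound 2 to compound 3 (0.10 log units; within the scatter) is therefore small. For compound 3 the estimated value is 280 nM with an expected range from 120 nM to 650 nM in this assay.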

Compound 3, half-maximal inhibitory concentration: 210 nM
Beside the measured number, compound 3's estimate is 1.3-fold (0.12 log units) above it; the range from low to high includes it.
By their numbers in this assay, from the lowest: compounds 3, 2 and 1 (each within the scatter of the next).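

In this assay, vinyl in place of oxiran-2-yl on this saturated ring carbon gives a 1.0-fold lower number from compound 2 to compound 3 (0.02 log units; within the scatter), so this first isolated pair shows that the three-membered ring can be exchanged here without a step beyond the scatter. With vinyl held constant, methyl in place of hydrogen on the saturated chain carbon gives a 1.5-fold lower number from compound 1 to compound 3 (0.18 log units; within the scatter), which also stays within the scatter. No available evidence bears on these results. Still open, going by these compounds, is whether ethyl, an amine or a carboxylic acid on this ring carbon would also leave the number within the scatter.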